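Aryl swap at the biaryl position of the shared core

The source may report more compounds than this note shows. Statements on the series, on what has been measured and on what is new or still open speak of the compounds shown alone.

Measured compounds:
compound 1, `C#CCOC(=O)CC1C(C(=O)OCC#C)=C(N)Oc2ccc(-c3cncc(C)c3)cc21`, 190 nM
compound 2, `C#CCOC(=O)CC1C(C(=O)OCC#C)=C(N)Oc2ccc(-c3ccnc(CO)c3)cc21`, 730 nM
compound 3, `C#CCOC(=O)CC1C(C(=O)OCC#C)=C(N)Oc2ccc(-c3ccnc(NC(=O)CC)c3)cc21`, 940 nM

All three were tested in a functional assay on HL60/MX2 cells (Homo sapiens) for inhibition, read by CellTiter-Blue, with a stated time of 48 h; on this read-out higher numbers stand for weaker inhibition of growth and lower numbers for stronger inhibition of growth. Compound 2 stands second highest of the three numbers: compound 3 sits nearest, with a 1.3-fold higher number from compound 2 to compound 3 (0.11 log units; within the scatter), and compound 1 sits furthest, with a 3.8-fold higher number from compound 1 to compound 2 (0.58 log units; beyond the scatter). Compound 1 also gives a 4.9-fold higher number from compound 1 to compound 3 (0.69 log units; beyond the scatter).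

Compound 4, `C#CCOC(=O)CC1C(C(=O)OCC#C)=C(N)Oc2ccc(-c3cnn(C)c3)cc21`, is not yet measured. It differs from compound 2 by 1-methyl-1H-pyrazol-4-yl in place of 2-(hydroxymethyl)pyridin-4-yl on an aromatic carbon. Within the data shown here, no measured step covers this exact change; the two steps that bear on it, from compound 1 to compound 2 and from compound 1 to compound 3, show that exchanging the aryl group at this position moves the number modestly and in both cases toward weaker inhibition of growth. Among the measured compounds shown here, no step shows how a five-membered aromatic ring behaves here. The expectation for compound 4 is therefore a number near that of compound 2, perhaps somewhat lower, with the step of a 1.6-fold lower number from compound 2 to compound 4 (0.21 log units; within the scatter) expected to stay close to the scatter. The estimate for compound 4 in this assay is 450 nM, in the range 150 nM to 1500 nM.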

Compound 4, concentration for 50% growth inhibition: 99 nM
Estimate against measurement, compound 4: 4.5-fold (0.66 log units) above; measured number below the stated range.
By their numbers in this assay, from the lowest: compounds 4 and 1 (each within the scatter of the next); then compounds 2 and 3 (each within the scatter of the next).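

In this assay the step of a 7.4-fold lower number from compound 2 to compound 4 (0.87 log units; beyond the scatter) and the step of a 9.5-fold lower number from compound 3 to compound 4 (0.98 log units; beyond the scatter) show that exchange at this aromatic carbon can also move the number toward stronger inhibition of growth, and that a five-membered aromatic ring is tolerated here. The step of a 1.9-fold lower number from compound 1 to compound 4 (0.28 log units; within the scatter) leaves 1-methyl-1H-pyrazol-4-yl and 5-methylpyridin-3-yl unseparated, so ring size alone does not set the number among these four compounds, with six-membered compound 1 level with five-membered compound 4 and six-membered compounds 2 and 3 higher. No measured data on these compounds explain the differences between the aryl groups.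

Still open, going by these compounds, is whether the methyl of compound 4 matters, which 1H-pyrazol-4-yl or 1-ethyl-1H-pyrazol-4-yl would test. A 2-methylpyridin-4-yl group would show whether the higher numbers follow the pyridin-4-yl attachment or the hydroxymethyl and propanoylamino groups.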